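This account rests on a few compounds, and the source may have more. Where it says the series, first, only, none or still open, it means among the compounds named here.

In an ADME assay on A549 cells (Homo sapiens) for cytotoxicity, read by CellTiter-Glo (on this read-out higher numbers stand for lower toxicity in this test and lower numbers for higher toxicity in this test), the measured compounds are:
compound 1 `Cc1c(Cc2ccccc2)c(=O)oc2cc(OCC(O)CNCC3CC3)ccc12`, with a result that is a limit of the assay, > 100000 nM
compound 2 `Cc1c(Cc2ccc(Cl)cc2)c(=O)oc2cc(OCC(O)CN3CCC(C(N)=O)CC3)ccc12`, with 40000 nM

Compound 2 carries the only number shown. The one other result, for compound 1, is a limit: the limit of > 100000 nM in this assay, at which 1 of the 2 values shown sits. The step goes from compound 2 to compound 3 `COC(=O)c1ccc(Cc2c(C)c3ccc(OCC(O)CN4CCC(C(N)=O)CC4)cc3oc2=O)cc1`. The change is methoxycarbonyl in place of chloro on an aromatic carbon. No measured pair shows a comparable change, so nothing shown fixes its size. In this assay the step is expected to be none beyond the scatter, with a 1.3-fold higher number from compound 2 to compound 3 (0.10 log units; within the scatter) as the estimated step. Compound 3 is therefore expected at 50000 nM, between 15000 nM and 150000 nM.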

Compound 3, half-maximal cytotoxic concentration: > 100000 nM
Compound 3: no number, only a limit; the forecaster's own chance of this, stated with the estimate: 30%; middle value at least 2.0-fold (0.30 log units) from the limit.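

In this assay methoxycarbonyl in place of chloro on this aromatic carbon gives an at least 2.5-fold higher number from compound 2 to compound 3 (0.39 log units; beyond the scatter) and so points to lower toxicity in this test. On these data alone, compound 3 gives > 100000 nM as a limit of the assay, so the full size of the step stays unknown. Further changes that lower toxicity could not be ranked at this end of the scale: the limit of > 100000 nM in this assay, at which 2 of the 3 values shown sit.

As far as these compounds go, whether any replacement of chloro would do the same remains open, and a carboxylic acid or an amine here would test that. From the compounds shown here alone, whether this change acts alike with the side chain of compound 1 also remains open.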